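A few compounds are considered here, and "the series" means these few. Any claim that something is new, unique, unknown or untested is made for them only; others in the source may bear on it.

Measured so far:
compound 1 `CCCCCCCCCCCC(=O)OC[C@H](CSC[C@@H](N)C(=O)NC(C)(C)CO)OC(=O)CCCCCCCCCCC` 15500 nM
compound 2 `CCCCCCCCCCCC(=O)OC[C@H](CSC[C@@H](N)C(=O)NCCCC(C)(C)CO)OC(=O)CCCCCCCCCCC` 30700 nM
compound 3 `CCCCCCCCCCCC(=O)OC[C@H](CSC[C@@H](N)C(=O)NC1(CO)CC1)OC(=O)CCCCCCCCCCC` 265 nM

All three compounds were tested in an assay on HEK293 cells for agonist activity at Toll-like receptor 2 (Homo sapiens); on this read-out lower numbers stand for an effect already at smaller amounts and higher numbers for an effect only at larger amounts of compound. Compound 3 stands lowest of the three: the step from compound 1 to compound 3 is a 58-fold lower number from compound 1 to compound 3 (1.77 log units; beyond the scatter), and the step from compound 2 to compound 3 is a 120-fold lower number from compound 2 to compound 3 (2.06 log units; beyond the scatter). Both steps lie beyond the scatter, so compound 3 is the most potent compound measured here. Between compound 1 and compound 2 the change is a 2.0-fold higher number from compound 1 to compound 2 (0.30 log units; within the scatter).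

Compound 4 `CCCCCCCCCCCC(=O)OC[C@H](CSC[C@@H](N)C(=O)NCCOCCOS(=O)(=O)O)OC(=O)CCCCCCCCCCC` has not yet been measured. Its difference from compound 3 is 2-(2-(sulfooxy)ethoxy)ethyl in place of 1-(hydroxymethyl)cyclopropyl on an amide-type nitrogen. Going by the values given here, no measured step covers this replacement directly. What bears on it is that in both steps leading to compound 3 the 1-(hydroxymethyl)cyclopropyl group came with large lower numbers, and compound 4 gives that group up. Compound 4 is therefore expected to show a step of a 15-fold higher number from compound 3 to compound 4 (1.18 log units; beyond the scatter) in this assay, that is towards higher numbers. The estimate for compound 4 is 4000 nM, with a range from 500 nM to 25000 nM.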

Compound 4, half-maximal effective concentration: 61 nM
For compound 4 the middle estimate is 66-fold (1.82 log units) above the measured one, outside the stated range (below it).
By their numbers in this assay, from the lowest: compound 4; then compound 3; then compounds 1 and 2 (each within the scatter of the next).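

In this assay, the 1-(hydroxymethyl)cyclopropyl group on the amide-type nitrogen turns out not to be required for a low number: the ring-free 2-(2-(sulfooxy)ethoxy)ethyl group gives a 4.3-fold lower number from compound 3 to compound 4 (0.64 log units; beyond the scatter) and makes compound 4 the most potent of the four. The two earlier ring-free groups stand far higher, with a 250-fold lower number from compound 1 to compound 4 (2.41 log units; beyond the scatter) and a 500-fold lower number from compound 2 to compound 4 (2.70 log units; beyond the scatter) showing that the absence of a ring does not by itself decide the outcome at this place. Nothing available here accounts for these steps.

On these data alone, what remains open is whether the terminal sulfooxy group or the ethoxy chain matters more. A 2-(2-hydroxyethoxy)ethyl group, a carboxylic acid at the chain end, or a longer chain bearing the same sulfooxy group would help separate the two.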